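Resolving a racemic urea into a single enantiomer

The compounds below may be only part of what the source reports. "The series", "measured", "known", "first", "only" and "open" are said of these compounds alone.

Measured so far:
compound 1 `O=C(Nc1cccc2[nH]ncc12)NC1CCOc2cc(OC(F)(F)F)ccc21`: 8 nM
compound 2 `CC(C)(C)c1ccc2c(c1)OCCC2NC(=O)Nc1cccc2[nH]ncc12`: 43 nM

In a functional assay for antagonist activity at transient receptor potential cation channel subfamily V member 1 (Homo sapiens), read by calcium flux (a lower number here means a stronger inhibitor, a higher number a weaker inhibitor), compound 2 gives the highest of the two numbers; its nearest neighbour is compound 1, with a 5.4-fold higher number from compound 1 to compound 2 (0.73 log units; beyond the scatter). Compound 3 `CC(C)(C)c1ccc2c(c1)OCC[C@@H]2NC(=O)Nc1cccc2[nH]ncc12` differs from compound 2 only in that (the two compounds have the same atoms and bonds; at least one stereo element is drawn with a configuration in one of them and without one in the other: 1 of 1 stereo elements differ; a stereocentre at a saturated ring carbon is drawn without a configuration in compound 2 and S in compound 3). Among the compounds with values here, no measured step bears on such a change; the difference between compound 1 and compound 2 concerns a substituent, not stereochemistry. A single enantiomer may carry most, or little, of the racemate's activity. For compound 3 a number near that of compound 2 is therefore expected, a 1.4-fold lower number from compound 2 to compound 3 (0.16 log units; within the scatter), with wide uncertainty: estimated 30 nM, range 8 nM to 150 nM.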

Compound 3, half-maximal inhibitory concentration: 1200 nM
The estimate for compound 3 lay 40-fold (1.60 log units) below the measured number; measured number above the stated range.
By their numbers in this assay, from the lowest: compound 1; then compound 2; then compound 3.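

In this assay, fixing the saturated ring carbon as S gives a 28-fold higher number from compound 2 to compound 3 (1.45 log units; beyond the scatter), so the spatial arrangement at this one carbon matters a great deal. If compound 2 is a mixture of both forms, the S form cannot account for its activity, which would then lie mainly with the R form. The comparison rests on one structural fact: the fact that one of compounds 2 and 3 is drawn with a defined configuration and the other without, at the place where they differ

Going by these compounds, how the R form itself performs remains open. So does whether the same preference holds with trifluoromethoxy, as in compound 1, or with another group such as trifluoromethyl.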